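A few compounds are considered here, and "the series" means these few. Any claim that something is new, unique, unknown or untested is made for them only; others in the source may bear on it.

Of the compounds shown here, two sharing one core have been measured in a functional assay on SW-620 cells (Homo sapiens) for antiproliferative activity, read by MTT assay, with a stated time of 72 h; a higher number here means a weaker inhibitor, a lower number a stronger inhibitor. Compound 1 `CCCCc1cn(C[C@H](O)[C@H]2OC(=O)C(OCc3ccccc3)=C2OCc2ccccc2)nn1` gives 47500 nM in this assay. Among the compounds with values here, compound 2 `O=C1O[C@H]([C@@H](O)Cn2cc(CNS(=O)(=O)c3ccc(Cl)cc3)nn2)C(OCc2ccccc2)=C1OCc1ccccc1` gives 18000 nM in this assay, the lowest of the two numbers, and the only measured step, a 2.6-fold lower number from compound 1 to compound 2 (0.42 log units; beyond the scatter), is the sole guide to how the group hanging from the five-membered ring matters. Compound 3 `O=C1O[C@H]([C@@H](O)Cn2cc(-c3cc(F)cc(F)c3)nn2)C(OCc2ccccc2)=C1OCc1ccccc1` differs from compound 2 by 3,5-difluorophenyl in place of (((4-chlorophenyl)sulfonyl)amino)methyl on an aromatic carbon. Within the data shown here, no measured step covers this particular swap, so its size and direction cannot be read from the data; the step from compound 1 to compound 2 shows only that changing the group at that position moves the number modestly. For compound 3 the expected step is therefore a 1.1-fold higher number from compound 2 to compound 3 (0.05 log units; within the scatter), with no firm direction. Compound 3 is estimated at 20000 nM, with a likely range from 6000 nM to 60000 nM.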

Compound 3, half-maximal inhibitory concentration: > 100000 nM
Compound 3: no number, only a limit; the forecaster's own chance of this, stated with the estimate: 10%; at least 5.0-fold (0.69 log units) between middle value and limit.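

Compound 3 gives a limit and not a number in this assay: the limit of > 100000 nM in this assay, at which 1 of the 3 values shown sits. Putting 3,5-difluorophenyl on this aromatic carbon gives an at least 5.5-fold higher number from compound 2 to compound 3 (0.74 log units; beyond the scatter), and the same group in place of butyl gives an at least 2.1-fold higher number from compound 1 to compound 3 (0.32 log units; beyond the scatter). The earlier pair showed this position moving the number only downward, whereas these steps show that the group here can also push it upward, so the outcome depends on which group sits on this carbon.

The true size of both upward steps cannot be read from a limit. Also open, from the compounds shown here alone, is whether the change follows from the two fluorines or from a benzene ring sitting directly on the five-membered ring, a question that plain phenyl and benzyl groups at this position would help to answer.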